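Allylamino to ethylamino: compound 3 against compound 2

The compounds below may be only part of what the source reports. "The series", "measured", "known", "first", "only" and "open" are said of these compounds alone.

Of the compounds shown here, two have been measured so far. In a functional assay on Huh-7 cells (Homo sapiens) for cytotoxicity, read by resazurin assay, with a stated time of 48 h (on this read-out lower numbers stand for stronger inhibition and higher numbers for weaker inhibition), compound 1 `CCOc1ccc(NC(=O)c2c(N)n[nH]c2Nc2ccccc2)cc1` gives 4320 nM. Compound 2 `C=CCNc1[nH]nc2nnn(-c3ccc(OCC)cc3)c(=O)c12` gives 4940 nM in this assay, the higher of the two numbers; the gap to compound 1 lies within the scatter, so the two stand level. Among the measured compounds shown here, no pair that differs in one place has been measured, so no step size is established for this series.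

Compound 3 `CCNc1[nH]nc2nnn(-c3ccc(OCC)cc3)c(=O)c12` is yet to be tested. It differs from compound 2 by methyl in place of vinyl on a saturated chain carbon bound to a nitrogen on an aromatic ring. The change takes out the double bond of the allyl chain and leaves the rest of the molecule untouched. For the measured compounds named here, with no measured step to guide the estimate, a change of this size is expected to move the number by no more than the scatter, in either direction. The expected step of a 1.1-fold higher number from compound 2 to compound 3 (0.05 log units; within the scatter) is small. Compound 3 is estimated at 5500 nM, in the range 2500 nM to 12000 nM.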

Compound 3, half-maximal inhibitory concentration: 14400 nM
The estimate for compound 3 lay 2.6-fold (0.42 log units) below the measured number, and the stated range ends below it.
By their numbers in this assay, from the lowest: compounds 1 and 2 (each within the scatter of the next); then compound 3.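

Among the compounds shown here, this is the first measured step: in this assay, methyl in place of vinyl on a saturated chain carbon bound to a nitrogen on an aromatic ring gives a 2.9-fold higher number from compound 2 to compound 3 (0.46 log units; beyond the scatter) and so weaker inhibition. The position therefore responds to a small edit, since allylamino to ethylamino removes only one heavy atom and the double bond outside aromatic rings, yet the step lies beyond the scatter. No measurement on hand speaks to a cause for this step.

A single step leaves the double bond and the chain length unseparated, and a saturated propyl chain at this place would tell them apart. Also open, on these data alone, is how the number responds to a free amine or a benzyl group here.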